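Adding a pyridin-3-yl to the phenyl of compound 1

The compounds below may be only part of what the source reports. "The series", "measured", "known", "first", "only" and "open" are said of these compounds alone.

Compound 1 `c1ccc(-c2nc3cccnc3n2C2CCCC2)cc1` is the reference point of this series. Among the measured compounds shown here, in a functional assay on MDA-MB-231 cells (Homo sapiens) for cytotoxicity, read by MTT assay, with a stated time of 24 h (a higher number here means a weaker inhibitor, a lower number a stronger inhibitor), compound 1 gives 3000 nM, the highest of the three numbers measured so far. Compound 3 `N#Cc1ccc(-c2nc3cccnc3n2C2CCCC2)cc1F` gives 2000 nM in this assay, a value that sits within the usual scatter of the number for compound 1, so the two cannot be told apart. For the measured compounds named here, compound 2 `FC(F)(F)Oc1cccc(-c2nc3cccnc3n2C2CCCC2)c1` gives 262 nM, and the change an 11-fold lower number from compound 1 to compound 2 (1.06 log units; beyond the scatter) is the one step in the set that bears directly on the reference compound.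

Compound 4 `c1cncc(-c2ccc(-c3nc4cccnc4n3C3CCCC3)cc2)c1` is the compound not yet measured. It differs from compound 1 in one place: pyridin-3-yl in place of hydrogen on an aromatic carbon. The step from compound 1 to compound 2 shows that a single substituent on the phenyl ring can move the number a long way downward; whether a pyridin-3-yl does the same is not shown by any measured pair, and compound 3 shows that another substituted phenyl stays close to compound 1. The expectation for compound 4 is therefore a modest move downward, a 2.0-fold lower number from compound 1 to compound 4 (0.30 log units; within the scatter), with wide uncertainty. Compound 4 is estimated to give 1500 nM in this assay, within a range from 400 nM to 5000 nM.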

Compound 4, half-maximal inhibitory concentration: > 10000 nM
Compound 4: a limit, no number; the forecaster's own chance of this, stated with the estimate: 5%; middle value at least 6.6-fold (0.82 log units) from the limit.
By their numbers in this assay, from the lowest: compound 2; then compounds 3 and 1 (each within the scatter of the next). At a limit, above all of these: compound 4.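

In this assay compound 4 gives > 10000 nM, which is a limit of the assay and not a number: the limit of > 10000 nM in this assay, at which 1 of the 4 values shown sits.

Pyridin-3-yl in place of hydrogen, set para to a large group on the six-membered aromatic ring of carbon only, gives an at least 3.3-fold higher number from compound 1 to compound 4 (0.52 log units; beyond the scatter). The earlier step, an 11-fold lower number from compound 1 to compound 2 (1.06 log units; beyond the scatter), had shown only a downward move for a single added group on this ring, whereas this change shows that a single added group on the same ring can also move the number upward, so the direction of the change depends on the group that enters or on where it sits, and the two steps do not separate these.

The compounds shown leave open whether the ring nitrogen of pyridin-3-yl matters for this move, which a plain phenyl in the same place would separate, or whether a smaller group there, such as a methoxy or an amine, would keep the number close to that of compound 1. Going by these compounds, how far compound 4 lies past its limit also stays open, so the size of its step has only a lower bound.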